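A bromo substituent on the weakest of three analogues

A few compounds are considered here, and "the series" means these few. Any claim that something is new, unique, unknown or untested is made for them only; others in the source may bear on it.

Compound 3 `O=C(Nc1ccc(Oc2ccnc3[nH]ccc23)c(F)c1)c1cc(-c2ccccc2)ncn1` gives 4640 nM in a functional assay on MCF7 cells (Homo sapiens) for cytotoxicity, read by MTT assay, with a stated time of 72 h (on this read-out lower numbers stand for stronger inhibition and higher numbers for weaker inhibition), the highest number of the three compounds measured. Compound 1 `O=C(Nc1ccc(Oc2ccnc3[nH]ccc23)cc1)c1cc(-c2ccccc2)ncn1` gives 20 nM in this assay, and compound 2 `Cc1ccc(-c2cc(C(=O)Nc3ccc(Oc4ccnc5[nH]ccc45)cc3)ncn2)cc1` gives 1620 nM. The two measured steps both run from compound 1 and both point the same way: an 81-fold higher number from compound 1 to compound 2 (1.91 log units; beyond the scatter) and a 230-fold higher number from compound 1 to compound 3 (2.37 log units; beyond the scatter). Going by the values given here, compound 3 therefore sits well apart from the other two, and the only step of a similar kind is the one to compound 2.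

Compound 4 `O=C(Nc1ccc(Oc2ccnc3[nH]ccc23)c(F)c1)c1cc(-c2ccc(Br)cc2)ncn1` differs from compound 3 by bromo in place of hydrogen on an aromatic carbon, on an aromatic carbon of a six-membered aromatic ring of carbon only, para to a large group; cut one bond further out, the change reads phenyl to 4-bromophenyl. The step that bears on this is an 81-fold higher number from compound 1 to compound 2 (1.91 log units; beyond the scatter), where a small group likewise entered in place of a hydrogen on an aromatic carbon and the number rose sharply. Among the compounds with values here, no step shows what a second change does on top of the fluoro already present in compound 3.

On that basis compound 4 is expected to show a higher number than compound 3, by about a 3.2-fold higher number from compound 3 to compound 4 (0.51 log units; beyond the scatter). The estimate for compound 4 in this assay is 15000 nM, with a range from 4000 nM to 60000 nM.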

Compound 4, half-maximal inhibitory concentration: 10300 nM
Compound 4: middle estimate off by 1.5-fold (0.16 log units), on the high side; the measured number falls inside the stated range.
By their numbers in this assay, from the lowest: compound 1; then compound 2; then compound 3; then compound 4.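

In this assay, putting bromo in place of hydrogen on an aromatic carbon, para to a large group, gives a 2.2-fold higher number from compound 3 to compound 4 (0.35 log units; beyond the scatter), so the change from phenyl to 4-bromophenyl still raises the number on a compound that already carries the fluoro. This step is modest and points the same way as an 81-fold higher number from compound 1 to compound 2 (1.91 log units; beyond the scatter), so both substitutions shown on this outer ring raise the number, although the two steps differ in the entering group and in the presence of the fluoro, and neither can be used to size the other. Compound 3 also proves not to mark an upper end for this series in this assay, and nothing available explains the rise or its size.

The compounds shown leave open how far the 4-bromophenyl group would move the number on the core of compound 1, which has no fluoro and so offers the cleaner comparison with the methyl step. They also leave open whether an amine or a carboxylic acid at this same place would raise the number further or bring it back toward that of compound 1 at 20 nM.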